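Nitrogen substituent variation on the shared core: compound 4

This account rests on a few compounds, and the source may have more. Where it says the series, first, only, none or still open, it means among the compounds named here.

Measured compounds:
Compound 1 `CCCC(C(C)C)n1ccc2cc(/C(C)=C/C(=O)Nc3ccccc3OCCCC(=O)O)ccc21` gives 7.2 nM in an assay on Prostate gland for inhibition of steroid 5-alpha-reductase (Rattus norvegicus); a lower number here means a stronger inhibitor, a higher number a weaker inhibitor.
Compound 2 `C/C(=C\C(=O)Nc1ccccc1OCCCC(=O)O)c1ccc2c(ccn2C(C(C)C)C(C)C)c1` gives 14 nM in this assay.
Compound 3 `C/C(=C\C(=O)Nc1ccccc1OCCCC(=O)O)c1ccc2c(ccn2Cc2ccc(C(C)(C)C)cc2)c1` gives 170 nM in this assay.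

Compound 3 stands highest of the three numbers; from compound 2 to compound 3 the step was a 12-fold higher number from compound 2 to compound 3 (1.08 log units; beyond the scatter) and from compound 1 to compound 3 it was a 24-fold higher number from compound 1 to compound 3 (1.37 log units; beyond the scatter), while a 1.9-fold higher number from compound 1 to compound 2 (0.29 log units; within the scatter). Compound 4 `CCCCC(c1ccccc1)n1ccc2cc(/C(C)=C/C(=O)Nc3ccccc3OCCCC(=O)O)ccc21` differs from compound 3 by 1-phenylpentyl in place of 4-(tert-butyl)benzyl on an aromatic nitrogen. Compound 4 thus returns to a branched saturated carbon on the aromatic nitrogen, as in compounds 1 and 2, though with a phenyl in place of one alkyl branch. The two large steps bear on this: both point to a lower number when the benzyl is replaced, so compound 4 is expected to lie in this assay at 25 nM (range 8 nM to 80 nM), a step estimated as a 6.8-fold lower number from compound 3 to compound 4 (0.83 log units; beyond the scatter).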

Compound 4, half-maximal inhibitory concentration: 9.8 nM
Beside the measured number, compound 4's estimate is 2.6-fold (0.41 log units) above it; the measured number falls inside the stated range.
By their numbers in this assay, from the lowest: compounds 1, 4 and 2 (each within the scatter of the next); then compound 3.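

In this assay, 1-phenylpentyl and 4-(tert-butyl)benzyl have the same heavy-atom count and one aromatic ring each, yet the swap gives a 17-fold lower number from compound 3 to compound 4 (1.24 log units; beyond the scatter) on the aromatic nitrogen. A phenyl can also stand on the branched carbon in place of an alkyl branch: a 1.4-fold lower number from compound 2 to compound 4 (0.15 log units; within the scatter) and a 1.4-fold higher number from compound 1 to compound 4 (0.13 log units; within the scatter) are both within the scatter. Nothing available explains the large step.

As far as these compounds go, the change moves the branching and removes the tert-butyl together, so their separate shares remain unknown. From the compounds shown here alone, an unsubstituted benzyl or an amine on the phenyl remains open.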